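The source may report more compounds than this note shows. Statements on the series, on what has been measured and on what is new or still open speak of the compounds shown alone.

Of the compounds shown here, three have been measured in a functional assay on the whole organism (strain albino) for inhibition, with Rattus norvegicus as the target, read by paw edema, with a stated time of 1 h, at a dose of 0.28 mmol/kg by the oral route; on this read-out higher numbers stand for more inhibition at the one dose given (going by the name of the read-out) and lower numbers for less inhibition: compound 1 `C=CCn1c(SCC(=O)c2ccccc2)nnc1-c1ccccc1` gives 43%, compound 2 `C=CCn1c(SCC(=O)c2ccccc2)nnc1-c1ccc(OC)cc1` gives 49%, and compound 3 `CCn1c(SC/C(=N/O)c2ccccc2)nnc1-c1ccc(OC)cc1` gives 69%.

Compound 2 and compound 1 differ in one place, namely (hydrogen in place of methoxy on an aromatic carbon). The step that went with it was a number 6 percentage points lower from compound 2 to compound 1 (within the scatter). How the core of compound 3 differs from the core of compound 2 is not broken down here; what the numbers show is that compound 3 stands highest of the three in this assay, with compound 2 nearest and compound 1 furthest, both gaps beyond the scatter.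

Compound 4 `CCn1c(SC/C(=N/O)c2ccccc2)nnc1-c1ccccc1` has not yet been measured in this assay. Among the compounds with values here, it differs from compound 3 by hydrogen in place of methoxy on an aromatic carbon, at the same place as before, so it is the same change as the one between compound 2 and compound 1. On that basis the step is expected to be small, about a number 6 percentage points lower from compound 3 to compound 4 (within the scatter), because the step already measured was a number 6 percentage points lower from compound 2 to compound 1 (within the scatter). Compound 4 is therefore estimated at 63% in this assay, most likely between 50% and 76%.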

Compound 4, a percentage reported as inhibition, in the whole organism at one dose (the size of the read-out at that dose, not a potency): 65%
Compound 4: middle estimate off by 2 percentage points, on the low side; the measured number falls inside the stated range.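

In this assay, going from 4-methoxyphenyl to phenyl on the core of compound 3 went with a number 4 percentage points lower from compound 3 to compound 4 (within the scatter), and the same change gave matching steps on the two cores: the same change on two cores in this assay, a number 6 percentage points lower (within the scatter) from compound 2 to compound 1 and a number 4 percentage points lower (within the scatter) from compound 3 to compound 4, 2 percentage points apart, within the scatter of two such steps. The change therefore carries from one core to the other in this series as a step too small to be told apart from the usual scatter, at the one dose given. It does not show that methoxy has any real effect on inhibition on either core, and two cores give no rule for any other core in the series.

The compounds shown leave open what a chlorine, a nitro group or an amine would do at that place on the ring, where only methoxy and hydrogen appear here. Also open, going by these compounds, is what a longer chain, such as propyl, would do on the core in this assay.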